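Nitro in Place of Ethoxy on an Inactive Starting Point

The compounds below may be only part of what the source reports. "The series", "measured", "known", "first", "only" and "open" are said of these compounds alone.

Compound 1 `CCOc1ccccc1OCCSC(=S)N[C@H]1CCOC1=O` was tested in a functional assay on MGC-803 cells (Homo sapiens) for antiproliferative activity, read by MTT assay, with a stated time of 72 h; on this read-out lower numbers stand for stronger inhibition and higher numbers for weaker inhibition. In this assay compound 1 gives > 64000 nM, which is a limit of the assay rather than a measured number. Compound 2 `O=C(CNc1ccccc1Cl)N[C@H]1CCOC1=O` shows the same outcome: in this assay compound 2 gives > 64000 nM, again a limit. Compound 1 therefore stands at the limit of > 64000 nM in this assay, at which 2 of the 2 values shown sit, with no number of its own to rank it.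

Compound 3 `O=C1OCC[C@@H]1NC(=S)SCCOc1ccccc1[N+](=O)[O-]` has not yet been tested. It differs from compound 1 in one place: nitro in place of ethoxy on an aromatic carbon. For the measured compounds named here, because both values shown sit at the limit of > 64000 nM in this assay, at which 2 of the 2 values shown sit, no measured step exists from which to read how such a change moves activity. The expected step is no clear movement beyond the scatter, a number no higher from compound 1 to compound 3 (the limit leaves the size open). Compound 3 is accordingly estimated at 64000 nM, with a likely range from 20000 nM to 150000 nM, and most probably again only a limit.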

Compound 3, half-maximal inhibitory concentration: 47000 nM
The estimate for compound 3 lay 1.4-fold (0.13 log units) above the measured number, within the range that was stated.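

For the compounds shown here, compound 3 is the first compound here to give a true number in this assay, 47000 nM, so this aromatic carbon, ortho to a large group, now has a reading that is not a limit. With nitro in place of ethoxy, the change is an at least 1.3-fold lower number from compound 1 to compound 3 (0.13 log units; that floor lies within the scatter); this is only a floor and not the true size of the step, as compound 1 has a limit and no number of its own. The other values shown stay at one limit of the assay: the limit of > 64000 nM in this assay, at which 2 of the 3 values shown sit.

As far as these compounds go, what remains open is how far the number really moves with this change, and whether it depends on nitro itself. An amine or a carboxylic acid on the same aromatic carbon would show whether other groups there also give a measurable number.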